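The compounds below may be only part of what the source reports. "The series", "measured", "known", "first", "only" and "open" are said of these compounds alone.

Compound 3 `CCS(=O)(=O)N1CCN(Cc2ccc(Nc3nccc(Oc4c(C)cc(/C=C/C#N)cc4C)n3)cc2)CC1` carries an ethylsulfonyl group on a ring nitrogen at the edge of the shared core. In an ADME assay on MT4 cells (Homo sapiens) for cytotoxicity, read by MTT assay (on this read-out higher numbers stand for lower toxicity in this test and lower numbers for higher toxicity in this test), compound 3 gives 4600 nM. Compound 2 `Cc1cc(/C=C/C#N)cc(C)c1Oc1ccnc(Nc2ccc(CN3CCCN(S(=O)(=O)C(C)C)CC3)cc2)n1` is a relative that differs in several places; in this assay compound 2 gives 4640 nM, and this number and that of compound 3 lie within the usual scatter of each other, so neither can be set apart from the other. Compound 1 `Cc1cc(C#N)cc(C)c1Oc1ccnc(Nc2ccc(CN3CCCN(S(=O)(=O)C4CC4)CC3)cc2)n1` is another relative with several differences; in this assay compound 1 was reported as "not active" (no number reported), with no number given. Compound 4 `C=CC(=O)N1CCN(Cc2ccc(Nc3nccc(Oc4c(C)cc(/C=C/C#N)cc4C)n3)cc2)CC1` has not yet been measured. It differs from compound 3 in one place: vinylcarbonyl in place of ethylsulfonyl on an amine nitrogen in a ring. Within the data shown here, no pair of measured compounds shows this exact change, so there is no measured step to lean on. The step of a 1.5-fold lower number from compound 3 to compound 4 (0.19 log units; within the scatter) is expected to be small, pointing toward a lower number, and hardly beyond the scatter. Compound 4 is expected to give 3000 nM in this assay, most likely somewhere between 1000 nM and 9000 nM.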

Compound 4, half-maximal cytotoxic concentration: 5210 nM
The estimate for compound 4 lay 1.7-fold (0.24 log units) below the measured number; low and high end bracket the measured number.
By their numbers in this assay, from the lowest: compounds 3, 2 and 4 (each within the scatter of the next).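

In this assay, putting vinylcarbonyl in place of ethylsulfonyl on this amine nitrogen in a ring gives a 1.1-fold higher number from compound 3 to compound 4 (0.05 log units; within the scatter) and so leaves the read-out where it was. Among these compounds, compounds 1, 2 and 3 differ from each other in several places, so this pair is the first to isolate a change at this position, and here two groups of different make-up, one with sulfur and one without, cannot be told apart in this test. No measurement shown explains why they read alike.

A bare ring amine with only a hydrogen on this nitrogen, a carboxylic acid, or a longer chain such as butylsulfonyl could still read differently. Going by these compounds, whether the same swap reads alike on the relatives, compound 1 and compound 2, also remains open.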